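Swapping the Benzyl Substituent on Compound 2

The source may report more compounds than this note shows. Statements on the series, on what has been measured and on what is new or still open speak of the compounds shown alone.

Of the compounds shown here, two have been measured so far in a functional assay on CHO/Galpha16 cells for antagonist activity at prostaglandin E2 receptor EP4 subtype (Homo sapiens), read by calcium flux, with a stated time of 15 min; a higher number here means a weaker inhibitor, a lower number a stronger inhibitor. Compound 1 `CCC1CCc2c(sc(CCc3ccc(F)cc3)c2C(=O)N[C@@H](C)c2ccc(C(=O)O)cc2)C1` gives 649 nM. Compound 2 `CC(C)c1ccc(Cc2sc3c(c2C(=O)N[C@@H](C)c2ccc(C(=O)O)cc2)CCOC3)cc1` gives 2.7 nM, the lowest of the two numbers, and its gap to compound 1 lies well beyond the scatter of the assay; the two differ at several points of their structures, so the numbers only show that compound 2 is the stronger inhibitor of the pair.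

Compound 3 `C[C@H](NC(=O)c1c(Cc2cccc(Cl)c2)sc2c1CCOC2)c1ccc(C(=O)O)cc1` keeps the core of compound 2 and changes one group: 3-chlorophenyl in place of 4-isopropylphenyl on a saturated chain carbon bound to an aromatic carbon. Going by the values given here, no measured pair shows the effect of this particular change, so the expectation rests only on compound 2 as the starting point. A change to a smaller ring substituent of this kind is expected to shift the number by a modest amount in the direction of weaker inhibition, though a result within the scatter cannot be ruled out.

The estimated step from compound 2 to compound 3 is a 3.7-fold higher number from compound 2 to compound 3 (0.57 log units; beyond the scatter). Compound 3 is expected to give about 10 nM in this assay, with a likely range from 2.5 nM to 60 nM.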

Compound 3, half-maximal inhibitory concentration: 3.2 nM
Beside the measured number, compound 3's estimate is 3.1-fold (0.49 log units) above it; low and high end bracket the measured number.
By their numbers in this assay, from the lowest: compounds 2 and 3 (each within the scatter of the next); then compound 1.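

In this assay, placing 3-chlorophenyl where 4-isopropylphenyl stood gives a 1.2-fold higher number from compound 2 to compound 3 (0.07 log units; within the scatter), so this read-out cannot tell the two compounds apart. Going by these compounds alone, this is the first pair that differs in one place only, and it shows that, on this shared core, the saturated chain carbon bound to an aromatic carbon can carry either of these two substituted phenyl groups with no difference beyond the scatter. No measurement here explains why the two groups read alike.

This single step swaps the substituent and also moves it around the ring, so the contribution of each change cannot be separated; 4-chlorophenyl and 3-isopropylphenyl would be the groups that pull them apart. On these data alone, it also remains open how far this tolerance extends, for instance whether plain phenyl, or a phenyl ring carrying an amine or a carboxylic acid, would read like compound 2 and compound 3 or would fall away from them.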